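Hydroxy in Place of a Chain Amine on Compound 1

The source may hold more compounds than are shown below. What is called first, only, known or untested is meant among the compounds shown, and "the series" means these compounds.

Measured so far:
compound 1, `CNCCCNc1c(C(=O)NCc2ccc(F)cc2)nc(Br)c2cccnc12`: 11000 nM
compound 2, `N[C@H]1CC[C@H](Nc2c(C(=O)NCc3ccccc3)nc(Br)c3cccnc23)CC1`: 7000 nM
compound 3, `O=CNCCCCCCNc1nc(C(=O)NCc2ccc(F)cc2)c(O)c2ncccc12`: 16000 nM

In a functional assay on MDA-MB-435 cells (Homo sapiens) for cytotoxicity, read by MTT assay, with a stated time of 72 h (a higher number here means a weaker inhibitor, a lower number a stronger inhibitor), compound 1 gives 11000 nM. Compound 1 stands second highest of the three numbers, yet its gaps to compound 2 and to compound 3 both fall within the usual scatter, so the three read alike and all are weak inhibitors. Compound 4, `O=C(NCc1ccc(F)cc1)c1nc(Br)c2cccnc2c1NCCO`, has not yet been measured. It differs from compound 1 by hydroxy in place of (methylamino)methyl on a saturated chain carbon, two bonds along the chain from a nitrogen on an aromatic ring. Among the compounds with values here, no step between measured compounds is available as a guide, and the three known numbers sit close together. The step from compound 1 to compound 4 is expected to be small, a 1.4-fold higher number from compound 1 to compound 4 (0.13 log units; within the scatter), leaning if anything toward a higher number. Compound 4 is estimated at 15000 nM, with a range from 6000 nM to 40000 nM.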

Compound 4, half-maximal inhibitory concentration: > 20000 nM
Compound 4: only a limit was reported (the forecaster's own chance of this, stated with the estimate: 20%); middle value at least 1.3-fold (0.12 log units) away from the limit.
By their numbers in this assay, from the lowest: compounds 2, 1 and 3 (each within the scatter of the next, the first and the last beyond it). At a limit, above all of these: compound 4.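

In this assay compound 4 gives > 20000 nM, which is a limit and not a number. Hydroxy in place of (methylamino)methyl is the first single change that can be read in this series, and it gives an at least 1.8-fold higher number from compound 1 to compound 4 (0.25 log units; that floor lies within the scatter). At this saturated chain carbon, then, hydroxy brings no stronger inhibition than the chain amine of compound 1.

On these data alone, how large the step really is stays open. Also open, as far as these compounds go, is whether a carboxylic acid or a longer chain ending in hydroxy at this position would give a lower number.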